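Ring Size on the Chain: From Compound 2 to Compound 4

This account rests on a few compounds, and the source may have more. Where it says the series, first, only, none or still open, it means among the compounds named here.

Compound 2 `c1ccc2c(c1)CC2CCCN1CCN(c2cccc3c2OCCO3)CC1` gives 646 nM in an assay on isolated protein for binding affinity to 5-hydroxytryptamine receptor 1B (Rattus norvegicus) (on this read-out lower numbers stand for stronger inhibition and higher numbers for weaker inhibition), which is the highest of the three numbers measured. Compound 3 `c1ccc2c(c1)CCC2CCN1CCN(c2cccc3c2OCCO3)CC1` gives 417 nM, and compound 1 `c1ccc2c(c1)CC2CN1CCN(c2cccc3c2OCCO3)CC1` gives 214 nM. The change from compound 2 to compound 3 is a 1.5-fold lower number from compound 2 to compound 3 (0.19 log units; within the scatter), a step made by the same kind of ring enlargement that is now in question, though at a different place on the chain. Compound 4 `c1ccc2c(c1)CCC2CCCN1CCN(c2cccc3c2OCCO3)CC1` keeps the chain length of compound 2 and carries a group of 9 heavy atoms (9 carbon; one five-membered non-aromatic ring of carbon only, one six-membered aromatic ring of carbon only) in place of a group of 8 heavy atoms (8 carbon; one four-membered non-aromatic ring of carbon only, one six-membered aromatic ring of carbon only), on a saturated chain carbon, three bonds along the chain from an amine nitrogen in a ring. Among the measured compounds shown here, the only measured step that bears on this change is the one from compound 2 to compound 3, which stayed within the scatter, so the step of a 1.4-fold lower number from compound 2 to compound 4 (0.16 log units; within the scatter) is expected to be small, if anything towards a slightly lower number. Compound 4 is therefore estimated to give 450 nM in this assay, with a likely range from 200 nM to 1000 nM.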

Compound 4, inhibition constant: 204 nM
Estimate against measurement, compound 4: 2.2-fold (0.34 log units) above, within the range that was stated.
By their numbers in this assay, from the lowest: compounds 4, 1, 3 and 2 (each within the scatter of the next, the first and the last beyond it).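

Replacing the group with the four-membered ring by 2,3-dihydro-1H-inden-1-yl, three bonds along the chain from an amine nitrogen in a ring, gives a 3.2-fold lower number from compound 2 to compound 4 (0.50 log units; beyond the scatter) in this assay and so moves the number by more than the usual scatter of repeated measurements. The earlier step, with the five-membered ring two bonds along the chain, gave only a 1.5-fold lower number from compound 2 to compound 3 (0.19 log units; within the scatter) and so could not show a clear change. Ring size at the position three bonds along the chain therefore makes a measurable difference, though a modest one.

As far as these compounds go, whether the trend continues to a 1,2,3,4-tetrahydronaphthalen-1-yl group, with its six-membered non-aromatic ring, or holds on a longer chain remains open. Nothing given here explains why the five-membered ring gives the lower number at this position.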